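Methyl on the Phenyl Ring of a Thioamide Pyridazinone

This account rests on a few compounds, and the source may have more. Where it says the series, first, only, none or still open, it means among the compounds named here.

Measured compounds:
compound 1 `N=C(S)CCn1ncccc1=O` gives 28.8%
compound 2 `N=C(S)CCn1nc(-c2ccccc2)ccc1=O` gives 53.7%
compound 3 `Cc1ccc(=O)n(CCC(=N)S)n1` gives 73.9%

All three were tested in a functional assay on the whole organism (stomach) for inhibition, with Rattus norvegicus as the target, at a dose of 100 mg/kg by the intraduodenal route; on this read-out higher numbers stand for more inhibition at the one dose given (going by the name of the read-out) and lower numbers for less inhibition. Compound 1 sits at the bottom of the three numbers. The step of a number 24.9 percentage points higher from compound 1 to compound 2 (beyond the scatter) comes from the change (phenyl in place of hydrogen on an aromatic carbon). The step of a number 45.1 percentage points higher from compound 1 to compound 3 (beyond the scatter) comes from the change (methyl in place of hydrogen on an aromatic carbon), and compound 3 stands above compound 2 by a number 20.2 percentage points higher from compound 2 to compound 3 (beyond the scatter), which places compound 3 at the top of the three.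

Compound 4 `Cc1ccc(-c2ccc(=O)n(CCC(=N)S)n2)cc1` has not been measured. It differs from compound 2 by methyl in place of hydrogen on an aromatic carbon. Within the data shown here, this is the same kind of change as the one from compound 1 to compound 3, but not the same: there the methyl entered on an aromatic carbon of a six-membered aromatic ring with 2 nitrogen, next to the ring nitrogen, meta to a group of 5 heavy atoms and para to a group of 1 heavy atom, whereas here it enters on a six-membered aromatic ring of carbon only, para to a large group. The two cores themselves differ by phenyl in place of hydrogen on an aromatic carbon.

With the place of the methyl unlike the measured one, the size of the earlier step cannot simply be carried over. Among the measured compounds shown here, compound 4 is expected to show a number 6.3 percentage points higher from compound 2 to compound 4 (within the scatter) in this assay, a smaller step than the one from compound 1 to compound 3. The estimate for compound 4 is 60%, expected to lie between 40% and 80%.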

Compound 4, a percentage reported as inhibition, in the whole organism at one dose (the size of the read-out at that dose, not a potency): 18.2%
Compound 4: the middle estimate sits 41.8 percentage points above what was measured; measured number outside the range, below it.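

In this assay, placing methyl on an aromatic carbon of a six-membered aromatic ring of carbon only, para to a large group, gives a number 35.5 percentage points lower from compound 2 to compound 4 (beyond the scatter), which leaves compound 4 the lowest of the four numbers. A change that reads the same on paper therefore does not carry from one core to the other in this series, since the two steps run in opposite directions and lie far apart: the same change on two cores in this assay, a number 45.1 percentage points higher (beyond the scatter) from compound 1 to compound 3 and a number 35.5 percentage points lower (beyond the scatter) from compound 2 to compound 4, 80.6 percentage points apart, beyond the scatter of two such steps This does not show that the core alone decides the outcome, since the two methyl groups also occupy different rings and different places, and one pair of steps at a single dose cannot separate these factors or give any reason for the reversal.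

The compounds shown leave open whether the fall belongs to methyl itself or would follow any group at that place, as a chlorine atom, a methoxy group or a carboxylic acid there on compound 2 could tell. They also leave open whether methyl elsewhere on the ring of carbon only, or a longer chain such as ethyl at the same place, would move the number in the same direction.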